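Adding a methyl to compound 2

A few compounds are considered here, and "the series" means these few. Any claim that something is new, unique, unknown or untested is made for them only; others in the source may bear on it.

Within the data shown here, in a functional assay on MDA-MB-231 cells (Homo sapiens) for inhibition, read by MTT assay, with a stated time of 48 h (a lower number here means a stronger inhibitor, a higher number a weaker inhibitor), compound 1 `COc1cc(-c2cc(=O)[nH]c3c(O)c(OC)ccc23)cc([Se]C)c1OC` gives 69 nM and compound 2 `COc1cc(-c2cc(=O)[nH]c3c(O)c(OC)ccc23)cc(SC)c1OC` gives 70 nM, so compound 2 stands level with its only measured neighbour. Among the measured compounds shown here, the single measured step is a 1.0-fold higher number from compound 1 to compound 2 (0.01 log units; within the scatter). It exchanges the selenium-bearing group for the sulfur-bearing group and leaves the rest of the structure unchanged.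

Compound 3 `COc1cc(-c2c(C)c(=O)[nH]c3c(O)c(OC)ccc23)cc(SC)c1OC` differs from compound 2 by one change: methyl in place of hydrogen on an aromatic carbon. This is methyl in place of hydrogen on an aromatic carbon, two atoms from the ring nitrogen. The measured step lies at a different place on the molecule and does not show what this methyl will do. For the measured compounds named here, no measured pair in this assay tests such a methyl, so the size of the step remains poorly constrained. The working expectation starts from compound 2 at 70 nM, with no shift beyond the scatter and a wide margin on both sides. The expected step is a 1.3-fold higher number from compound 2 to compound 3 (0.11 log units; within the scatter). Compound 3 is estimated at 90 nM, with an expected range of 20 nM to 450 nM.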

Compound 3, half-maximal inhibitory concentration: 133 nM
Estimate against measurement, compound 3: 1.5-fold (0.17 log units) below; low and high end bracket the measured number.
By their numbers in this assay, from the lowest: compounds 1, 2 and 3 (each within the scatter of the next).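

In this assay, among these compounds, the step is a 1.9-fold higher number from compound 2 to compound 3 (0.28 log units; within the scatter), which gives the first reading at this position, on the aromatic carbon two atoms from the ring nitrogen. The earlier pair spoke only to the exchange of the selenium-bearing group for the sulfur-bearing group, whereas this pair shows that the added methyl, one more heavy atom, leaves the number within the scatter of compound 2. With one pair, a small real effect of the methyl cannot be separated from repeat-to-repeat variation, so the position reads as accepting methyl in this assay and nothing firmer. No measured property in the material at hand bears on this step, and no reason can be attached to it.

The compounds shown leave open whether the position holds anything larger than methyl, such as an ethyl or a longer chain, and how an amine or a carboxylic acid would read at the same place. They also leave open whether the same methyl on compound 1, with its selenium-bearing group, would give a comparable step.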